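The source may report more compounds than this note shows. Statements on the series, on what has been measured and on what is new or still open speak of the compounds shown alone.

Compound 1 `O=C(/C(=C/c1ccc(Cl)cc1)CCl)c1ccccc1` is the starting point of this set. In a functional assay on SW1573 cells (Homo sapiens) for inhibition, read by sulforhodamine B assay, with a stated time of 48 h (a higher number here means a weaker inhibitor of growth, a lower number a stronger inhibitor of growth), compound 1 gives 3900 nM. Compound 2 `O=C(/C(=C/c1ccc(Cl)cc1Cl)CCl)c1ccccc1` carries one alteration relative to compound 1, namely (chloro in place of hydrogen on an aromatic carbon), and in this assay compound 2 gives 3800 nM; the step of a 1.0-fold lower number from compound 1 to compound 2 (0.01 log units; within the scatter) shows that this change left the number essentially where it was. Compound 3 `CC(=O)OC/C(=C\c1ccc(Cl)cc1)C(=O)c1ccc(Cl)cc1` is built on a different core; how its core differs from that of compound 1 is not broken down here. In this assay compound 3 gives 3400 nM, a number that sits together with those of compound 1 and compound 2 within the usual scatter. Compound 4 `CC(=O)OC/C(=C\c1ccc(Cl)cc1Cl)C(=O)c1ccc(Cl)cc1` has not yet been measured. It differs from compound 3 by chloro in place of hydrogen on an aromatic carbon, the same change that separates compound 1 from compound 2. Since that change produced only a 1.0-fold lower number from compound 1 to compound 2 (0.01 log units; within the scatter), the step from compound 3 to compound 4 is expected to be similarly small, no change at the digits printed from compound 3 to compound 4 (within the scatter). Compound 4 is therefore estimated to give about 3400 nM in this assay, most likely somewhere between 1900 nM and 6200 nM.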

Compound 4, concentration for 50% growth inhibition: 3400 nM
Beside the measured number, compound 4's estimate shows no gap at the digits printed, within the range that was stated.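

In this assay, the step from 4-chlorophenyl to 2,4-dichlorophenyl on the core of compound 3 gives no change at the digits printed from compound 3 to compound 4 (within the scatter), so this chloro, ortho to a large group, leaves the number in the same place on this core as on the core of compound 1. Set side by side, the two steps agree: the same change on two cores in this assay, a 1.0-fold lower number (0.01 log units; within the scatter) from compound 1 to compound 2 and no change at the digits printed (within the scatter) from compound 3 to compound 4, 1.0-fold (0.01 log units) apart, within the scatter of two such steps. This shows that the change carries across these two cores as a step too small to read, but it does not show that the cores would respond alike to a change that moved the number, and it says nothing about any third core.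

The compounds shown carry only hydrogen or chloro on this aromatic carbon, so what a methoxy group, an amine or a carboxylic acid would do there remains open. Also open, going by these compounds, is whether any group on this aromatic carbon can shift the growth inhibition on either core.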